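Series notes: aryl variation on the shared core, next step

The source may report more compounds than this note shows. Statements on the series, on what has been measured and on what is new or still open speak of the compounds shown alone.

Measured so far in a functional assay (muscle tissue) with Cavia porcellus as the target; on this read-out lower numbers stand for an effect already at smaller amounts and higher numbers for an effect only at larger amounts of compound:
compound 1 `COC(=O)C1=C(C)N=C(C)/C(=C(\O)OC)C1c1cccc(O)c1` — 1000 nM
compound 2 `CCc1ccccc1C1C(C(=O)OC)=C(C)N=C(C)/C1=C(\O)OC` — 6.46 nM
compound 3 `COC(=O)C1=C(C)N=C(C)/C(=C(\O)OC)C1c1ccccc1Br` — 7.59 nM

Compound 1 gives the highest number of the three. The two steps away from it are both large and in the same direction: a 150-fold lower number from compound 1 to compound 2 (2.19 log units; beyond the scatter) and a 130-fold lower number from compound 1 to compound 3 (2.12 log units; beyond the scatter). Between compound 2 and compound 3 the difference is a 1.2-fold higher number from compound 2 to compound 3 (0.07 log units; within the scatter), so those two cannot be ordered.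

Compound 4 `COC(=O)C1=C(C)N=C(C)/C(=C(\O)OC)C1c1cccc([N+](=O)[O-])c1` is the next case. It differs from compound 1 as follows: nitro in place of hydroxy on an aromatic carbon. For the measured compounds named here, this is a different kind of change from the two measured steps, which exchange the whole 3-hydroxyphenyl for another aryl; no measured step replaces the hydroxy alone on that aromatic carbon. Going by the values given here, what the measured steps do show is that compound 1, the only compound carrying the hydroxy, stands at the highest number, and that removing that group from the series has so far gone with a large decrease. On that basis a decrease is expected for compound 4 as well, though a smaller and less certain one than the measured steps, since the change itself is smaller. The step that this expectation means is a 10-fold lower number from compound 1 to compound 4 (1.00 log units; beyond the scatter). Compound 4 is therefore estimated at 100 nM in this assay, in the range 10 nM to 1000 nM.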

Compound 4, half-maximal effective concentration: 3.98 nM
Compound 4: the middle estimate sits 25-fold (1.40 log units) above what was measured, outside the stated range (below it).
By their numbers in this assay, from the lowest: compounds 4, 2 and 3 (each within the scatter of the next); then compound 1.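

In this assay, a change at this one aromatic carbon, meta to a large group, is enough on its own to give a large step: nitro in place of hydroxy gives a 250-fold lower number from compound 1 to compound 4 (2.40 log units; beyond the scatter) with the rest of compound 1 kept. The earlier large steps exchanged the whole aryl group, so they could not separate the identity of the group from its place on the ring; here the place stays the same and only the group changes. Nothing in the data shown bears on the cause of this step.

Compared with a hydrogen, an amine or a carboxylic acid on that same aromatic carbon, it remains open whether the hydroxy of compound 1 raises the number or the nitro of compound 4 lowers it. Also open, as far as these compounds go, is whether nitro would give a similar number elsewhere on the six-membered aromatic ring.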